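Adding a nitro group to compound 3

A few compounds are considered here, and "the series" means these few. Any claim that something is new, unique, unknown or untested is made for them only; others in the source may bear on it.

Compound 1 `CCOC(=O)c1cc(-c2ccc(OC)c([N+](=O)[O-])c2)c(-c2cc(OC)c(OC)c(OC)c2)s1`: 24000 nM
Compound 2 `COc1ccc(-c2cc(C(=O)O)sc2-c2cc(OC)c(OC)c(OC)c2)cc1[N+](=O)[O-]`: 43700 nM
Compound 3 `COc1ccc(-c2ccsc2-c2cc(OC)c(OC)c(OC)c2)cc1`: 7400 nM

All three compounds were tested in a functional assay on KB cells (Homo sapiens) for antiproliferative activity, read by MTT assay, with a stated time of 72 h; on this read-out lower numbers stand for stronger inhibition and higher numbers for weaker inhibition. Compound 3 gives 7400 nM, the lowest number of the three and clearly apart from the other two. Compound 4 `COc1ccc(-c2ccsc2-c2cc(OC)c(OC)c(OC)c2)cc1[N+](=O)[O-]` differs from it by one change: nitro in place of hydrogen on an aromatic carbon, ortho to a methoxy group. Within the data shown here, no measured step isolates this change. Among the measured compounds shown here, the only step available, a 1.8-fold higher number from compound 1 to compound 2 (0.26 log units; within the scatter), concerns a different place and stays within the scatter, so it offers little guidance. Compound 1 at 24000 nM and compound 2 at 43700 nM both carry the nitro group and both stand higher than compound 3, but each also carries a further carbonyl-containing group, so the two changes cannot be separated. A moderate rise in this assay is therefore expected, though its size is uncertain. The expected change is a 1.6-fold higher number from compound 3 to compound 4 (0.21 log units; within the scatter). For compound 4 the estimated value is 12000 nM, with an expected range of 3500 nM to 40000 nM.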

Compound 4, half-maximal inhibitory concentration: 21000 nM
For compound 4 the middle estimate is 1.8-fold (0.24 log units) below the measured one, within the range that was stated.
By their numbers in this assay, from the lowest: compound 3; then compounds 4, 1 and 2 (each within the scatter of the next, the first and the last beyond it).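

In this assay, among these compounds, the nitro group, ortho to a methoxy group, raises the number on its own (a 2.8-fold higher number from compound 3 to compound 4 (0.45 log units; beyond the scatter)), an effect the earlier compounds could not separate from their carbonyl-containing groups. With the nitro group in place, the carboxy group also carries a modest cost (a 2.1-fold lower number from compound 2 to compound 4 (0.32 log units; beyond the scatter)), whereas the ethoxycarbonyl group makes no readable difference (a 1.1-fold lower number from compound 1 to compound 4 (0.06 log units; within the scatter)). The higher number at this position therefore needs no carbonyl-containing group on the core of compound 4.

Nothing available here bears on the reason for these steps. Going by these compounds, whether an amine or a fluorine atom in the same place would give a number like that of the nitro group remains open, as does the effect of the carboxy or ethoxycarbonyl group on compound 3, which has no nitro group.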